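This account rests on a few compounds, and the source may have more. Where it says the series, first, only, none or still open, it means among the compounds named here.

Measured in a physicochemical assay for solubility, at pH 7.4; on this read-out lower numbers stand for lower solubility and higher numbers for higher solubility:
- compound 1 `CC[C@H](N)C(=O)N1CCc2c(C)c3c(n2-c2ccc(C(N)=O)c(c2)N[C@@H](C)[C@H](C)C1)CC(C)(C)CC3=O`: > 100 ug/mL (a limit of the assay)
- compound 2 `Cc1c2c(n3c1CCN(C(=O)C(C)(C)N)C[C@@H](C)[C@H](C)Nc1cc-3ccc1C(N)=O)CC(C)(C)CC2=O`: > 100 ug/mL (a limit of the assay)
- compound 3 `Cc1c2c(n3c1CCN(C(=O)C1(N)CC1)C[C@@H](C)[C@H](C)Nc1cc-3ccc1C(N)=O)CC(C)(C)CC2=O`: 7 ug/mL

Among the compounds with values here, compound 3 is the lowest of the three and the only one with an actual number. Compound 1 and compound 2 both stand at the limit of > 100 ug/mL in this assay, at which 2 of the 3 values shown sit.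

Compound 4 `Cc1c2c(n3c1CCN(C(=O)[C@H](C)O)C[C@@H](C)[C@H](C)Nc1cc-3ccc1C(N)=O)CC(C)(C)CC2=O` has 1-hydroxyethyl in place of 1-aminocyclopropyl on a carbonyl carbon.

Three measured steps change this same place. The step that the two limits leave unreadable from compound 1 to compound 2 cannot be sized. The steps of an at least 14-fold lower number from compound 1 to compound 3 (1.15 log units; beyond the scatter) and an at least 14-fold lower number from compound 2 to compound 3 (1.15 log units; beyond the scatter) are both large, and each brings 1-aminocyclopropyl in. Compound 4 takes that group out, which points to a higher number. However, 1-hydroxyethyl has not been measured in this series, so those steps suggest a direction more than a size, and a smaller rise is expected. The expected change is a 2.9-fold higher number from compound 3 to compound 4 (0.46 log units; beyond the scatter). For compound 4 the estimated value in this assay is 20 ug/mL, with an expected range from 4 ug/mL to 100 ug/mL.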

Compound 4, solubility: 60 ug/mL
Compound 4: middle estimate off by 3.0-fold (0.48 log units), on the low side; the range from low to high includes it.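

In this assay, 1-hydroxyethyl in place of 1-aminocyclopropyl on this carbonyl carbon gives an 8.6-fold higher number from compound 3 to compound 4 (0.93 log units; beyond the scatter), so the low value of compound 3 does not extend to every small group here, and a group without an amine can reach a much higher number. Against the two open-chain amino groups, the steps read an at least 1.6-fold lower number from compound 2 to compound 4 (0.22 log units; that floor lies within the scatter) and an at least 1.6-fold lower number from compound 1 to compound 4 (0.22 log units; that floor lies within the scatter). Neither step sets compound 4 firmly apart from the compound it is compared with, and the true gaps stay unknown: the limit of > 100 ug/mL in this assay, at which 2 of the 4 values shown sit.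

Still open, from the compounds shown here alone, is whether the higher number goes with the oxygen or with the loss of the three-membered ring, a question that 1-hydroxycyclopropyl on the same carbonyl carbon would address. The mirror-image form of 1-hydroxyethyl also remains an open comparison at this position.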